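Ester variation and microsomal stability in the butyl-pyrimidinone series

The source may hold more compounds than are shown below. What is called first, only, known or untested is meant among the compounds shown, and "the series" means these compounds.

Measured so far:
compound 1 `CCCCc1nc(C)c(CC(=O)OCC)c(=O)n1Cc1ccc(-c2ccccc2-c2noc(=O)[nH]2)cc1` — 46.6%; 46.5% (2 entries)
compound 2 `CCCCc1nc(C)c(CC(=O)OC2CC2)c(=O)n1Cc1ccc(-c2ccccc2-c2noc(=O)[nH]2)cc1` — 34.5%

In an ADME assay on microsomes from liver (Homo sapiens) for metabolic stability, with a stated time of 30 min (on this read-out lower numbers stand for a less stable compound and higher numbers for a more stable compound), compound 1 gives 46.6%; 46.5% (2 entries) and compound 2 gives 34.5%. The two entries of compound 1 agree closely (the several entries of compound 1 in this assay, 46.6%; 46.5% (2 entries)). On the only number shown for it, compound 2 stands below compound 1; a further entry for compound 2 gives no single number.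

Compound 3 `CC#CCOC(=O)Cc1c(C)nc(CCCC)n(Cc2ccc(-c3ccccc3-c3noc(=O)[nH]3)cc2)c1=O` is the next step from compound 2. The change is but-2-yn-1-yl in place of cyclopropyl on an oxygen next to a carbonyl group. For the measured compounds named here, no measured step of this kind stands beside it, so no direction can be read from the series itself.

For compound 3 in this assay, the expected step from compound 2 is a number 4.5 percentage points lower from compound 2 to compound 3 (within the scatter), a small shift downward that may still lie within the usual scatter. Compound 3 is therefore estimated at 30%, with a range from 15% to 45%.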

Compound 3, percent of the compound remaining: 32%
Beside the measured number, compound 3's estimate is 2 percentage points below it; measured number inside the range.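

Exchanging cyclopropyl for but-2-yn-1-yl on an oxygen next to a carbonyl group gives, in this assay, a number 2.5 percentage points lower from compound 2 to compound 3 (within the scatter), so at this place an open chain with a triple bond reads the same as a three-membered ring within the scatter. Compound 1 stands at 46.6%; 46.5% (2 entries) and compound 3 at 32%, so the butynyl ester does not restore the printed value of the ethyl ester. Nothing at hand gives a cause for the step from the cyclopropyl ester to the butynyl ester.

Still open, as far as these compounds go, is how a saturated longer chain, such as n-butyl, reads on the same oxygen in this assay. Also open, from the compounds shown here alone, is how an amide or a free carboxylic acid in place of the ester reads there.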